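Trimming the amide chain on a fluorophenyl indoline series

The source may report more compounds than this note shows. Statements on the series, on what has been measured and on what is new or still open speak of the compounds shown alone.

Measured so far:
compound 1 `CCC(=O)N1CCc2cc(CNC(=O)c3ccnn3C)ccc21`: 14%
compound 2 `CC(C)C(=O)N1CCc2cc(CNC(=O)c3ccc(F)cc3)ccc21`: 88%

In an assay on HEK293 cells for inhibition of Indoleamine 2,3-dioxygenase 1 (Homo sapiens), tested at 10 uM (a higher number here means more inhibition at the concentration tested (going by the name of the read-out), a lower number less inhibition), compound 2 gives the higher of the two numbers shown, and compound 1 sits far below it, beyond the scatter. Compound 3 `CCC(=O)N1CCc2cc(CNC(=O)c3ccc(F)cc3)ccc21` keeps the fluorophenyl amide of compound 2 and changes only the acyl chain: hydrogen in place of methyl on a saturated chain carbon bound to a carbonyl carbon and a saturated chain carbon. Within the data shown here, no measured pair isolates this change, so the expected step of a number 10 percentage points lower from compound 2 to compound 3 (within the scatter) is small, at most a modest loss within or near the scatter. Compound 3 is therefore estimated at 78%, with a range from 55% to 92%.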

Compound 3, a percentage reported as inhibition, at one concentration (the size of the read-out at that concentration, not a potency): 96%
The estimate for compound 3 lay 18 percentage points below the measured number; the measured number lies above the stated range.
By their numbers in this assay, from the lowest: compound 1; then compounds 2 and 3 (each within the scatter of the next).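

In this assay the change from isopropyl to ethyl gives a number 8 percentage points higher from compound 2 to compound 3 (within the scatter) and so leaves the read-out unchanged within the scatter, which shows that this methyl on the acyl chain can go without a measurable change at this level of inhibition. With propanoyl held constant, 4-fluorophenyl in place of 1-methyl-1H-pyrazol-5-yl gives a number 82 percentage points higher from compound 1 to compound 3 (beyond the scatter) and ties the large gap to that amide group alone. Nothing available bears on the reason for either step. Still open, as far as these compounds go, is whether acetyl or a longer chain such as butanoyl in place of propanoyl would keep this level, and whether a plain phenyl could stand in for 4-fluorophenyl.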